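A few compounds are considered here, and "the series" means these few. Any claim that something is new, unique, unknown or untested is made for them only; others in the source may bear on it.

Measured so far in a functional assay for inhibition, with Homo sapiens as the target; on this read-out lower numbers stand for stronger inhibition and higher numbers for weaker inhibition:
- compound 1 `CC(C)(C)Sc1c(CC(C)(C)C(=O)O)n(Cc2ccc(Cl)cc2)c2ccc(OCc3ccc4cc(F)c(F)cc4n3)cc12`: 7 nM
- compound 2 `CC(C)(C)Sc1c(CC(C)(C)C(=O)O)n(Cc2ccc(Cl)cc2)c2ccc(OCc3cccnc3)cc12`: 8 nM

Among the measured compounds shown here, compound 2 sits level with compound 1, the only other measured compound, so the series shows no spread yet. The next compound is compound 3 `CC(C)c1csc(COc2ccc3c(c2)c(SC(C)(C)C)c(CC(C)(C)C(=O)O)n3Cc2ccc(Cl)cc2)n1`, with this change: 4-isopropyl-1,3-thiazol-2-yl in place of pyridin-3-yl on a saturated chain carbon bound to an oxygen on an aromatic ring. In words, 4-isopropyl-1,3-thiazol-2-yl stands in place of pyridin-3-yl on a saturated chain carbon bound to an oxygen on an aromatic ring.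

For the measured compounds named here, only one measured step changes the group at this place: a 1.1-fold higher number from compound 1 to compound 2 (0.06 log units; within the scatter). That step stayed within the scatter even though the two groups differ considerably in size and ring count. As far as these compounds go, neither measured compound carries a five-membered aromatic ring or a sulfur atom at this place, so the new group itself is untested. The expected step is a 1.3-fold higher number from compound 2 to compound 3 (0.10 log units; within the scatter), which means nothing beyond the scatter in this assay and no firm direction. With a single step to go on, the range is kept wide. Compound 3 is estimated at 10 nM, with an expected range of 3 nM to 30 nM.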

Compound 3, half-maximal inhibitory concentration: 3 nM
For compound 3 the middle estimate is 3.3-fold (0.52 log units) above the measured one, within the range that was stated.
By their numbers in this assay, from the lowest: compound 3; then compounds 1 and 2 (each within the scatter of the next).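

In this assay, among the compounds shown here, 4-isopropyl-1,3-thiazol-2-yl in place of pyridin-3-yl on a saturated chain carbon bound to an oxygen on an aromatic ring gives a 2.7-fold lower number from compound 2 to compound 3 (0.43 log units; beyond the scatter) and is the first step at this place to lie beyond the scatter. The same group entering in place of the larger two-ring group of compound 1 gives a 2.3-fold lower number from compound 1 to compound 3 (0.37 log units; beyond the scatter), so compound 3 stands apart from both earlier compounds, and this place is shown to respond to the group it carries, which the step between compounds 1 and 2 could not show. Nothing at hand bears on why the number falls with this change.

The compounds shown do not separate the contribution of the isopropyl group from that of the five-membered aromatic ring, as the two enter together. As far as these compounds go, the unsubstituted 1,3-thiazol-2-yl, and the same ring with methyl or tert-butyl in place of isopropyl, would bear on that question, and the size of group this place accepts on the ring also remains open.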